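The source may report more compounds than this note shows. Statements on the series, on what has been measured and on what is new or still open speak of the compounds shown alone.

Compound 1 `Cc1c(O)ccc2c1[C@H](Cn1cc(-c3ccccc3)nn1)[C@@]13CC(=O)[C@@](C)(CC[C@@H]21)C3` gives > 20000 nM in a functional assay on A549 cells (Homo sapiens) for cytotoxicity, read by MTT assay, with a stated time of 4 days; on this read-out lower numbers stand for stronger inhibition and higher numbers for weaker inhibition; this is a limit of the assay, not a number.
Compound 2 `Cc1c(O)ccc2c1[C@H](Cn1cc(-c3ccc(Cl)cc3)nn1)[C@@]13CC(=O)[C@@](C)(CC[C@@H]21)C3` gives > 20000 nM; this too is a limit of the assay.

Compound 2 thus stands at the limit of this assay, where every value shown so far sits (the limit of > 20000 nM in this assay, at which 2 of the 2 values shown sit). Among the measured compounds shown here, the only measured step, a step that the two limits leave unreadable from compound 1 to compound 2, cannot be read, since both ends are limits, so no step of known size bears on the change to compound 3 `Cc1c(O)ccc2c1[C@H](Cn1cc(-c3ccccn3)nn1)[C@@]13CC(=O)[C@@](C)(CC[C@@H]21)C3`. That change is pyridin-2-yl in place of 4-chlorophenyl on an aromatic carbon. With nothing measured beyond the limit, the expectation for compound 3 rests on compound 2 itself, whose value > 20000 nM is a limit. Compound 3 is therefore expected to give about 30000 nM, in a range from 8000 nM to 100000 nM, most probably reported again only as a limit. The step that the limit leaves unreadable from compound 2 to compound 3 that this estimate means is expected to stay within the scatter, with no direction that can be read.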

Compound 3, half-maximal inhibitory concentration: > 20000 nM
Compound 3 ended at the assay's limit; the forecaster's own chance of this, stated with the estimate: 80%; the middle value lies beyond the limit too.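

Compound 1, compound 2 and compound 3 all give a limit of the assay rather than a number, so no step among them can be read: the limit of > 20000 nM in this assay, at which 3 of the 3 values shown sit.

Left open is whether phenyl, 4-chlorophenyl and pyridin-2-yl differ at all in this assay, and by how much.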